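Adding a Third Methoxy Group: Little Change Expected

This account rests on a few compounds, and the source may have more. Where it says the series, first, only, none or still open, it means among the compounds named here.

Of the compounds shown here, three sharing one core have been measured in a functional assay for inhibition, with a stated time of 5 min, tested at 1 mM; a higher number here means more inhibition at the concentration tested (going by the name of the read-out), a lower number less inhibition. Compound 1 `COc1ccc2[nH]cc(C(=O)/C(C#N)=C/C=C(\Cl)c3ccc(OC)c(OC)c3)c2c1` gives 58.2%, compound 2 `COc1ccc2[nH]cc(C(=O)/C(C#N)=C/C=C(\Cl)c3ccc(Br)cc3)c2c1` gives 54.5%, and compound 3 `COc1ccc(/C(Cl)=C/C=C(\C#N)C(=O)c2c[nH]c3ccccc23)cc1OC` gives 63.6%. Compound 1 stands second highest of the three numbers, yet its distance to each neighbour lies within the scatter: a number 3.7 percentage points lower from compound 1 to compound 2 (within the scatter), with 4-bromophenyl in place of 3,4-dimethoxyphenyl on a double-bonded chain carbon bound to a chlorine atom and a double-bonded chain carbon, and a number 5.4 percentage points higher from compound 1 to compound 3 (within the scatter), with hydrogen in place of methoxy on an aromatic carbon.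

Compound 4 `COc1ccc2[nH]cc(C(=O)/C(C#N)=C/C=C(\Cl)c3cc(OC)c(OC)c(OC)c3)c2c1` differs from compound 1 by methoxy in place of hydrogen on an aromatic carbon. The entering group sits ortho to a methoxy group and meta to a large group and to another methoxy group.

Neither measured step repeats this exact change, but each alters a methoxy-bearing part of the molecule and each stayed within the scatter, so no step beyond the scatter is expected in this assay; the expected step is a number 0.2 percentage points lower from compound 1 to compound 4 (within the scatter). Compound 4 is therefore estimated to give 58%, with a likely range from 45% to 71%.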

Compound 4, a percentage reported as inhibition, at one concentration (the size of the read-out at that concentration, not a potency): 50%
The estimate for compound 4 lay 8 percentage points above the measured number; the range from low to high includes it.
By their numbers in this assay, from the lowest: compounds 4, 2, 1 and 3 (each within the scatter of the next, the first and the last beyond it).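

In this assay, methoxy in place of hydrogen on this aromatic carbon, ortho to a methoxy group, gives a number 8.2 percentage points lower from compound 1 to compound 4 (within the scatter). This is the first step shown that places a group on this carbon itself, and it shows that a third methoxy group can sit on the ring without a step beyond the scatter. The read-out comes from a single concentration, so this describes the size of inhibition at that concentration, not a potency, and no measurement at hand gives a reason for the result.

As far as these compounds go, whether an amine, a carboxylic acid or a longer chain on this same carbon would also stay within the scatter remains open. From the compounds shown here alone, it is also open whether the methoxy group would give a similar step on the core of compound 3.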